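Methoxy removal at the benzylidene aryl in a hydrazinone series

This account rests on a few compounds, and the source may have more. Where it says the series, first, only, none or still open, it means among the compounds named here.

Measured compounds:
compound 1 `Cc1ccc(/C=C2/N=C(c3ccccc3)N(C(=O)COc3ccccc3)NC2=O)cc1` — "not active" (no number reported)
compound 2 `COc1ccc(/C=C2/N=C(c3ccccc3)N(C(=O)c3ccc(Cl)cc3)NC2=O)cc1` — 300 mg/kg

Going by the values given here, in a functional assay on the whole organism (strain albino) with Mus musculus as the target, with a stated time of 4 h (a lower number here means that less compound is needed, a higher number that more compound is needed for the effect), compound 2 gives 300 mg/kg, the only number in the set. Compound 1 is reported only as "not active" (no number reported), without a number, and gives no scale for comparison. Compound 3 `O=C1NN(C(=O)c2ccc(Cl)cc2)C(c2ccccc2)=N/C1=C/c1ccccc1` differs from compound 2 by hydrogen in place of methoxy on an aromatic carbon. Among the compounds with values here, no pair of measured compounds shows what this change does in this assay, so no step beyond the scatter is expected in either direction. For compound 3 the estimate is 300 mg/kg (range 150 mg/kg to 600 mg/kg), an expected step of no change at the digits printed from compound 2 to compound 3 (within the scatter) within the usual scatter.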

Compound 3, dose for half-maximal effect: 300 mg/kg
Beside the measured number, compound 3's estimate shows no gap at the digits printed; measured number inside the range.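

Going from 4-methoxyphenyl to phenyl in this assay gives no change at the digits printed from compound 2 to compound 3 (within the scatter) and is the first measured step for this change in the series. Methoxy is therefore not required on this aromatic carbon for compound 3 to keep a measurable dose, at least with the rest of the structure held as in compound 2.

From the compounds shown here alone, whether an amine or a carboxylic acid on this aromatic carbon would keep the dose remains open, and this single pair cannot show whether the result carries over to other acyl groups. No measured evidence on the reason for this result is at hand.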